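The source may report more compounds than this note shows. Statements on the series, on what has been measured and on what is new or still open speak of the compounds shown alone.

Compound 1 `CCCCc1nc(CCC)c(CCC(=O)OCC)c(=O)n1Cc1ccc(-c2ccccc2-c2nnn[nH]2)cc1` - "not determined" (no result reported)
Compound 2 `CCCCc1nc(C)c(CC(=O)N2CCCC2)c(=O)n1Cc1ccc(-c2ccccc2-c2nnn[nH]2)cc1` - 0.056 mg/kg

For the measured compounds named here, in an in vivo functional assay on the whole organism for inhibition, with Rattus norvegicus as the target (on this read-out lower numbers stand for an effect already at smaller amounts and higher numbers for an effect only at larger amounts of compound), compound 2 gives 0.056 mg/kg as the only number so far, and compound 1 has no number to set against it. Compound 3 `CCCCc1nc(C)c(CC(=O)N2CCOCC2)c(=O)n1Cc1ccc(-c2ccccc2-c2nnn[nH]2)cc1` differs from compound 2 by morpholin-4-yl in place of pyrrolidin-1-yl on a carbonyl carbon and so carries morpholin-4-yl in place of pyrrolidin-1-yl on a carbonyl carbon. Going by the values given here, no measured step shows what this swap does, so only a modest shift towards larger doses is expected, possibly none beyond the usual scatter. The estimate means a 1.8-fold higher number from compound 2 to compound 3 (0.25 log units; within the scatter) as the expected step. For compound 3 the estimated value is 0.1 mg/kg with a likely range from 0.03 mg/kg to 0.35 mg/kg once measured.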

Compound 3, dose for half-maximal effect: 0.018 mg/kg
Estimate against measurement, compound 3: 5.6-fold (0.74 log units) above; the whole stated range lies above it.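

In this assay, the group on the carbonyl carbon clearly affects the dose needed: morpholin-4-yl in place of pyrrolidin-1-yl gives a 3.1-fold lower number from compound 2 to compound 3 (0.49 log units; beyond the scatter). This position therefore accepts a six-membered ring with a second hetero atom, and the change goes beyond the usual scatter. Nothing available explains this step. As far as these compounds go, the two rings differ in both size and oxygen content, so the separate contribution of each stays open. Piperidin-1-yl, a six-membered ring without oxygen, would address that question, while dimethylamino would test whether a ring is needed at all.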